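The source may hold more compounds than are shown below. What is called first, only, known or untested is meant among the compounds shown, and "the series" means these compounds.

Compound 1 `COc1ccccc1Nc1nc(SCc2cn(Cc3ccccc3Cl)nn2)nc(-c2ccccc2)c1C#N` and compound 2 `Cc1ccccc1Nc1nc(SCc2cn(Cc3ccccc3Cl)nn2)nc(-c2ccccc2)c1C#N` share one core and differ at a single aromatic carbon. In a functional assay on ECa-109 cells (Homo sapiens) for inhibition, read by MTT assay, with a stated time of 72 h (on this read-out higher numbers stand for weaker inhibition and lower numbers for stronger inhibition), compound 1 gives 9670 nM, and in this assay compound 2 gives 9740 nM. The change between them is methoxy in place of methyl on an aromatic carbon, and it made a 1.0-fold lower number from compound 2 to compound 1 (0.00 log units; within the scatter).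

Compound 3 `Cc1ccc(Nc2nc(SCc3cn(Cc4ccccc4Cl)nn3)nc(-c3ccc(C(C)C)cc3)c2C#N)cc1` is built on a different core; how the core of compound 3 differs from the core of compound 2 is not broken down here. In this assay compound 3 gives 5080 nM, a number that sits within the usual scatter of both compound 1 and compound 2, so the three measured compounds are not separated from one another by this read-out.

Compound 4 `COc1ccc(Nc2nc(SCc3cn(Cc4ccccc4Cl)nn3)nc(-c3ccc(C(C)C)cc3)c2C#N)cc1` is yet to be measured. It stands to compound 3 as compound 1 stands to compound 2: the change is methoxy in place of methyl on an aromatic carbon. Going by the values given here, it is the same kind of change as the one from compound 2 to compound 1, not the same, since in compound 1 the group sits ortho to a large group, whereas in compound 4 it sits para to a large group.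

Because the earlier step was a 1.0-fold lower number from compound 2 to compound 1 (0.00 log units; within the scatter), compound 4 is expected to show a step of about a 1.0-fold lower number from compound 3 to compound 4 (0.01 log units; within the scatter) from compound 3 in this assay. The estimate for compound 4 in this assay is 5000 nM, expected to fall between 2500 nM and 10000 nM.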

Compound 4, half-maximal inhibitory concentration: 3580 nM
Compound 4: middle estimate off by 1.4-fold (0.15 log units), on the high side; the measured number falls inside the stated range.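

In this assay, methoxy in place of methyl on the aromatic carbon para to a large group gave a 1.4-fold lower number from compound 3 to compound 4 (0.15 log units; within the scatter), so the step stays within the scatter on this core too. Set beside the earlier step on the other core, the change carries across the two cores with no difference that this read-out can resolve: the same change on two cores in this assay, a 1.0-fold lower number (0.00 log units; within the scatter) from compound 2 to compound 1 and a 1.4-fold lower number (0.15 log units; within the scatter) from compound 3 to compound 4, 1.4-fold (0.15 log units) apart, within the scatter of two such steps. This shows that the swap left the number within the scatter in both pairs, even though the group sits in a different place on the two cores, but it does not show that the change has any real effect on inhibition, nor that it would behave alike on any further core.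

Whether an amine, a carboxylic acid or a longer chain in place of methoxy would move the number beyond the scatter stays open, since the compounds shown carry only methyl and methoxy at these carbons. Also open, as far as these compounds go, is how the swap reads when only the core changes and the group keeps the same place, and how it reads in cells other than those of this one assay.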